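Methyl branching at two nitrogen-bound chain carbons: series notes

A few compounds are considered here, and "the series" means these few. Any claim that something is new, unique, unknown or untested is made for them only; others in the source may bear on it.

Measured so far in an assay on HL-60 cells for agonist activity at vitamin D3 receptor (Homo sapiens), with a stated time of 96 h; a lower number here means that less compound is needed, a higher number that more compound is needed for the effect:
compound 1, `CCC(CC)(c1ccc(OCC(=O)C(C)(C)C)c(C)c1)c1ccc(C(=O)NCC(=O)OC)n1C`, gives 23 nM
compound 2, `CCn1c(C(=O)NCC(=O)OC)ccc1C(CC)(CC)c1ccc(OCC(=O)C(C)(C)C)c(C)c1`, gives 1830 nM
compound 3, `CCn1c(C(=O)NCCO)ccc1C(CC)(CC)c1ccc(OCC(O)C(C)(C)C)c(C)c1`, gives 5640 nM

Compound 3 gives the highest number of the three, with its steps to compound 1 and compound 2 beyond the scatter. How the core of compound 3 differs from the core of compound 1 is not broken down here.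

The change methyl in place of hydrogen on a saturated chain carbon bound to an aromatic nitrogen is measured as an 80-fold higher number from compound 1 to compound 2 (1.90 log units; beyond the scatter). Compound 4, `CCn1c(C(=O)N[C@@H](C)CO)ccc1C(CC)(CC)c1ccc(OCC(O)C(C)(C)C)c(C)c1`, carries the same kind of change, (methyl in place of hydrogen on a saturated chain carbon bound to an amide-type nitrogen and a saturated chain carbon). The place is not the same: in compound 2 the carbon is bound to an aromatic nitrogen, in compound 4 to an amide-type nitrogen and a saturated chain carbon.

Given the large step of an 80-fold higher number from compound 1 to compound 2 (1.90 log units; beyond the scatter) at a different place, only a modest move is expected here: compound 4 is expected to show a 1.6-fold higher number from compound 3 to compound 4 (0.20 log units; within the scatter) in this assay. Compound 4 is therefore estimated at 9000 nM, between 3000 nM and 30000 nM.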

Compound 4, half-maximal effective concentration: 1.06 nM
Compound 4: the middle estimate sits 8500-fold (3.93 log units) above what was measured; measured number outside the range, below it.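

In this assay, methyl in place of hydrogen on a saturated chain carbon bound to an amide-type nitrogen and a saturated chain carbon gives a 5300-fold lower number from compound 3 to compound 4 (3.73 log units; beyond the scatter). The same kind of change moves the number in opposite directions in the two pairs and cannot be carried from one core to the other as a fixed increment: the same change on two cores in this assay, an 80-fold higher number (1.90 log units; beyond the scatter) from compound 1 to compound 2 and a 5300-fold lower number (3.73 log units; beyond the scatter) from compound 3 to compound 4, 420000-fold (5.63 log units) apart, beyond the scatter of two such steps. The two steps differ in both core and place, and these compounds do not separate the two.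

Open, from the compounds shown here alone, is whether the same methyl branch on the amide side gives a comparable step on the core of compound 1. Also open, going by these compounds, is whether a longer chain at that carbon, or a carboxylic acid in place of the hydroxyl of the 1-(hydroxymethyl)ethyl group, retains the low number of compound 4.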